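Cinnamyl in place of ester on the imidazolone nitrogen

The source may report more compounds than this note shows. Statements on the series, on what has been measured and on what is new or still open speak of the compounds shown alone.

In a functional assay on the whole organism (B cells) with Mus musculus as the target (a lower number here means a smaller maximal response, a higher number a larger maximal response), compound 2 `CCOC(=O)Cn1c(=O)n(C2OC(CO)[C@@H](O)[C@H]2O)c2nc(N)nc(O)c21` gives 86%, the second highest of three numbers. Its nearest neighbour is compound 3 `C=CCSc1nc2c(O)nc(N)nc2n1C1OC(CO)[C@@H](O)[C@H]1O`, which gives 107%, higher by a margin beyond the scatter, while compound 1 `C=CCn1c(=O)n(C2OC(CO[Si](C)(C)C(C)(C)C)[C@@H](O)[C@H]2O)c2nc(N)nc(O)c21` lies furthest away with 5%. Compound 4 `Nc1nc(O)c2c(n1)n(C1OC(CO)[C@@H](O)[C@H]1O)c(=O)n2C/C=C/c1ccccc1` has not been measured in this assay; it differs from compound 2 as follows: 2-phenylethenyl in place of ethoxycarbonyl on a saturated chain carbon bound to an aromatic nitrogen. For the measured compounds named here, with no measured pair showing this change, the size of the step is uncertain, and a downward step is expected, possibly beyond the scatter, since the remaining shared partner compound 1 with a small chain on that nitrogen gives 5%. Compound 4 is therefore estimated at 60%, within 15% to 105%, an expected step of a number 26 percentage points lower from compound 2 to compound 4 (beyond the scatter).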

Compound 4, largest response reached (reported as maximal response), in percent of the reference or control that the assay uses: 73%
Estimate against measurement, compound 4: 13 percentage points below, and the stated range covers the measured number.
By their numbers in this assay, from the lowest: compound 1; then compound 4; then compound 2; then compound 3.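

In this assay, for the compounds shown here, the change from ethoxycarbonyl to 2-phenylethenyl on a saturated chain carbon bound to an aromatic nitrogen gives a number 13 percentage points lower from compound 2 to compound 4 (beyond the scatter) and is the first measured step at this position. The position therefore tolerates losing the ester and gaining an aromatic ring at a modest cost, with much of the response kept. No measurement at hand accounts for this step.

Still open, going by these compounds, is whether the step follows from losing the ester or from gaining the phenyl ring. A carboxylic acid, an amine or a longer saturated chain on this nitrogen could help separate the two.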